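The source may hold more compounds than are shown below. What is called first, only, known or untested is meant among the compounds shown, and "the series" means these compounds.

The three measured compounds share one core and differ only in the group on the nitrogen on the aromatic ring. Compound 1 `COc1ccc(S(=O)(=O)N2CCc3cccc(NC(=O)c4ccc(C#N)cc4)c32)cc1` carries a (4-cyanophenyl)carbonyl there, and in a functional assay on KB cells (Homo sapiens) for cytotoxicity (a higher number here means a weaker inhibitor, a lower number a stronger inhibitor), compound 1 gives 105 nM. Compound 2 `COc1ccc(S(=O)(=O)N2CCc3cccc(NS(=O)(=O)c4ccccc4)c32)cc1` carries a phenylsulfonyl instead, and in this assay compound 2 gives 650 nM; that change is a 6.2-fold higher number from compound 1 to compound 2 (0.79 log units; beyond the scatter). Compound 3 `COc1ccc(S(=O)(=O)N2CCc3cccc(NC(=O)Oc4ccccc4)c32)cc1` carries a phenoxycarbonyl. In this assay compound 3 reaches only the limit > 10000 nM, so no number is known for it. Compound 3 thus stands at the weak end of what has been measured, at the limit of > 10000 nM in this assay, at which 1 of the 3 values shown sits, and the steps leading to it were large: an at least 95-fold higher number from compound 1 to compound 3 (1.97 log units; beyond the scatter) and an at least 15-fold higher number from compound 2 to compound 3 (1.18 log units; beyond the scatter).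

Compound 4 `COc1ccc(S(=O)(=O)N2CCc3cccc(NC(=O)c4ccc(F)cc4)c32)cc1` differs from compound 3 in one place: 4-fluorophenyl in place of phenoxy on a carbonyl carbon. This puts 4-fluorophenyl on the carbonyl carbon, where compound 1 carries 4-cyanophenyl, and so largely undoes the change seen from compound 1 to compound 3. A large step toward stronger inhibition is therefore expected, an at least 66-fold lower number from compound 3 to compound 4 (1.82 log units; beyond the scatter). Compound 4 is expected to give about 150 nM in this assay, between 50 nM and 600 nM.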

Compound 4, half-maximal inhibitory concentration: 93 nM
Estimate against measurement, compound 4: 1.6-fold (0.21 log units) above, and the stated range covers the measured number.
By their numbers in this assay, from the lowest: compounds 4 and 1 (each within the scatter of the next); then compound 2. At a limit, above all of these: compound 3.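

Replacing cyano with fluoro on an aromatic carbon gives a 1.1-fold lower number from compound 1 to compound 4 (0.05 log units; within the scatter) and so leaves this assay effectively unchanged, which shows that the nitrile of compound 1 is not required for this level of activity. The nature of the link on the nitrogen makes a greater difference, with a 7.0-fold lower number from compound 2 to compound 4 (0.84 log units; beyond the scatter) when a (4-fluorophenyl)carbonyl replaces phenylsulfonyl and an at least 100-fold lower number from compound 3 to compound 4 (2.03 log units; beyond the scatter) when 4-fluorophenyl replaces phenoxy on the carbonyl carbon. The last of these steps has only a lower bound, since compound 3 has a limit rather than a number: the limit of > 10000 nM in this assay, at which 1 of the 4 values shown sits.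

The compounds shown do not reveal whether a plain benzoyl group, with no substituent on its ring, would match compound 1 and compound 4. They also leave open how an acetyl group, or a methoxy or an amine in place of the fluoro, would fare.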